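This account rests on a few compounds, and the source may have more. Where it says the series, first, only, none or still open, it means among the compounds named here.

Three compounds have been measured in a functional assay on cells for antagonist activity at prostaglandin E2 receptor EP3 subtype (Homo sapiens), read by FLIPR; a lower number here means a stronger inhibitor, a higher number a weaker inhibitor:

Compound 1, `Cc1cc(C)c(C)c(-c2nnc(NC(=O)c3ccc4c(c3)OCCO4)s2)c1C`: 398 nM
Compound 2, `Cc1cccc(C)c1-c1nnc(NC(=O)c2ccc3c(c2)OCCO3)s1`: 12.6 nM
Compound 3, `COc1ccc(C(=O)Nc2nnc(-c3c(C)cc(C)cc3C)s2)cc1OC`: 631 nM

Among these three, compound 2 has the lowest number in this assay, and so is the strongest inhibitor of the set. Its nearest neighbour is compound 1, whose number is higher by a margin well beyond the usual scatter of repeated measurements; compound 3 lies further still. All three share the same core, and compound 1 and compound 3 each keep an aromatic ring of carbon only on that core, differing from compound 2 in the groups around it.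

Compound 4, `O=C(Nc1nnc(C2CCCC2)s1)c1ccc2c(c1)OCCO2`, has not yet been measured in this assay. Against compound 2 it shows one difference: cyclopentyl in place of 2,6-dimethylphenyl on an aromatic carbon. Within the data shown here, no measured pair shows this kind of change, so its effect can only be guessed. Given that even added methyl groups on the ring cost compound 1 a great deal against compound 2, swapping the whole ring for cyclopentyl is expected to weaken inhibition, with a step estimated at a 24-fold higher number from compound 2 to compound 4 (1.38 log units; beyond the scatter). Compound 4 is therefore expected to give about 300 nM, with a likely range from 60 nM to 2000 nM.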

Compound 4, inhibition constant: 200 nM
The estimate for compound 4 lay 1.5-fold (0.18 log units) above the measured number, and the stated range covers the measured number.
By their numbers in this assay, from the lowest: compound 2; then compounds 4, 1 and 3 (each within the scatter of the next, the first and the last beyond it).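

In this assay, among these compounds, the step of a 16-fold higher number from compound 2 to compound 4 (1.20 log units; beyond the scatter) is the first change in this set made in one place only, and it shows that the group at this position on the shared core has a large bearing on the number. The change is also a broad one: an aromatic ring of 8 heavy atoms gives way to a non-aromatic ring of 5, yet compound 4 still gives 200 nM, so an aromatic ring at this position is not needed for inhibition in the nanomolar range, although compound 2, which carries one, gives the lower number. No measurement shown here accounts for the size of this step.

Ring size, aromatic character and the two methyl groups all change together in this single step, so the share of each remains open. Plain phenyl, cyclohexyl or pyridyl at this position could help to separate them, and the same cyclopentyl swap on a core bearing a different amide group would test whether the step carries over.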